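Amine variation on the shared core: expectation for compound 4

The source may hold more compounds than are shown below. What is called first, only, known or untested is meant among the compounds shown, and "the series" means these compounds.

The series varies the amine on the shared core. Compound 1 `COc1ccc2c(NC3CCCCCC3)nc(N3CCC(N4CCCC4)CC3)nc2c1` carries a cycloheptylamino group, and in an in vitro assay on B300-19 cells for displacement of a labelled ligand from C-C chemokine receptor type 4 (Homo sapiens), tested at 1 uM (a lower number here means less inhibition, a higher number more inhibition at the concentration tested (going by the name of the read-out)), compound 1 gives 0%. Compound 2 `COc1cc2nc(N3CCC(N4CCCC4)CC3)nc(N(C)C)c2cc1OC` carries a dimethylamino group in that place. In this assay compound 2 reaches only < 0%, which is a limit of the assay and not a number (the limit of < 0% in this assay, at which 1 of the 3 values shown sits). Compound 3 `COc1cc2nc(N3CCC(N4CCCC4)CC3)nc(N3CCCCC3)c2cc1OC` carries piperidin-1-yl, and in this assay compound 3 gives 19%. Compound 3 thus stands highest of the two numbers; the nearest number, that of compound 1, lies below it beyond the scatter, and the remaining value is a limit. Among the compounds with values here, the one measured step that bears on the next change is a number at least 19 percentage points higher from compound 2 to compound 3 (beyond the scatter), in which an acyclic dimethylamino group gave way to a ring.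

Compound 4 `CCNc1nc(N2CCC(N3CCCC3)CC2)nc2cc(OC)c(OC)cc12` differs from compound 3 by ethylamino in place of piperidin-1-yl on an aromatic carbon. This change runs the other way: the ring leaves and a small acyclic amine with one donor enters. A fall of roughly the size of the measured step is expected, namely a number 15 percentage points lower from compound 3 to compound 4 (beyond the scatter) as the estimate. Compound 4 is therefore expected to give 4%, within a range from -10% to 20%. A limit rather than a number, as seen for compound 2, remains possible.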

Compound 4, a percentage reported as inhibition, at one concentration (the size of the read-out at that concentration, not a potency): < 0%
Compound 4: a limit, no number; the forecaster's own chance of this, stated with the estimate: 25%; middle value at least 4 percentage points from the limit.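

In this assay compound 4 gives < 0%, which is a limit of the assay and not a number. Replacing the ring with a small acyclic amine on this aromatic carbon, next to the ring nitrogen, now has a measured step of its own: a number at least 19 percentage points lower from compound 3 to compound 4 (beyond the scatter). Until now, only the change from dimethylamino to piperidin-1-yl had been read at this position, and the result for ethylamino extends that picture, since among compounds 2, 3 and 4, which differ only here, piperidin-1-yl alone gives a number and both acyclic amines end at the same limit: the limit of < 0% in this assay, at which 2 of the 4 values shown sit.

The step from compound 2 to compound 4 cannot be read, so no order between dimethylamino and ethylamino can be stated. As far as these compounds go, it also remains open whether the number for compound 3 goes with a ring at this position in general or with piperidin-1-yl in particular, a question that pyrrolidin-1-yl, morpholin-4-yl or a longer chain such as n-butylamino in the same place would help to settle.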